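From Chloro to Fluoro on the Aromatic Ring

The source may report more compounds than this note shows. Statements on the series, on what has been measured and on what is new or still open speak of the compounds shown alone.

Three compounds share one core and differ only in the group on one aromatic carbon. In a functional assay on CHO cells for inhibition of transient receptor potential cation channel subfamily V member 1 (Homo sapiens) (on this read-out lower numbers stand for stronger inhibition and higher numbers for weaker inhibition), they give:

Compound 1, `Cc1ccc(/C=C/C(=O)Nc2ccc3c(c2)OCCO3)cc1`: 210 nM
Compound 2, `CC(C)c1ccc(/C=C/C(=O)Nc2ccc3c(c2)OCCO3)cc1`: 55 nM
Compound 3, `O=C(/C=C/c1ccc(Cl)cc1)Nc1ccc2c(c1)OCCO2`: 250 nM

Compound 3 carries the highest number of the three. Its gap to compound 1 is small: a 1.2-fold higher number from compound 1 to compound 3 (0.08 log units; within the scatter). Against compound 2 it is clearer: a 4.5-fold higher number from compound 2 to compound 3 (0.66 log units; beyond the scatter).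

Compound 4, `O=C(/C=C/c1ccc(F)cc1)Nc1ccc2c(c1)OCCO2`, has not yet been measured. It differs from compound 3 in one place: fluoro in place of chloro on an aromatic carbon, sitting para to a large group. Going by the values given here, no measured step exchanges one halogen for another, so the nearest guides are the two steps that put chloro in place of an alkyl group. They show a methyl and a chloro giving numbers within the scatter of each other, while the isopropyl of compound 2 gives a lower number. A single-atom swap such as fluoro for chloro is expected to move the number little, with the direction, if any, toward a higher number: a 1.4-fold higher number from compound 3 to compound 4 (0.15 log units; within the scatter). Compound 4 is therefore estimated at 350 nM, with a range from 150 nM to 900 nM.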

Compound 4, half-maximal inhibitory concentration: 1000 nM
The estimate for compound 4 lay 2.9-fold (0.46 log units) below the measured number, outside the stated range (above it).
By their numbers in this assay, from the lowest: compound 2; then compounds 1 and 3 (each within the scatter of the next); then compound 4.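

Methyl and chloro had given numbers within the scatter of each other at this position, so the group there seemed able to change with little effect on the number, but fluoro shows otherwise (a 4.0-fold higher number from compound 3 to compound 4 (0.60 log units; beyond the scatter); a 4.8-fold higher number from compound 1 to compound 4 (0.68 log units; beyond the scatter)). The range seen at this one aromatic carbon also widens (an 18-fold higher number from compound 2 to compound 4 (1.26 log units; beyond the scatter)), and exchanging one halogen atom for another proves enough to move the number beyond the scatter. Nothing available explains why fluoro and chloro differ here.

The compounds shown leave open where bromo, methoxy or tert-butyl on this carbon would fall relative to compound 2 and compound 4. They also leave open whether fluoro in place of chloro would have a similar effect at another carbon of the ring or on a different core.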